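The compounds below may be only part of what the source reports. "The series", "measured", "known", "first", "only" and "open" are said of these compounds alone.

For the measured compounds named here, in a functional assay on HepG2 cells (Homo sapiens) for antiproliferative activity, read by MTT assay, with a stated time of 48 h (a lower number here means a stronger inhibitor, a higher number a weaker inhibitor), compound 3 (`COc1cc2oc(-c3ccccc3)cc(=O)c2c(O)c1OCCCN1CCCC1`) gives 4300 nM as the only true number among the three compounds measured so far. Compound 1 (`O=c1cc(-c2ccccc2)oc2cc(O)c(OCCCCN3CCCCC3)c(O)c12`) gives > 100000 nM as a limit of the assay and not a number. Compound 2 (`O=c1cc(-c2ccccc2)oc2cc(O)c(OCCCCN3CCCC3)c(O)c12`) gives > 100000 nM as a limit too. Between these two lies a step that the two limits leave unreadable from compound 1 to compound 2 and it offers no usable size.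

Compound 4 (`O=c1cc(-c2ccccc2)oc2cc(O)c(OCCCN3CCCC3)c(O)c12`) arises from compound 3 by one change, hydrogen in place of methyl on an oxygen on an aromatic ring, or methoxy to hydroxy (hydrogen in place of methyl on an oxygen on an aromatic ring). Going by the values given here, no measured step covers this change. Compound 1 and compound 2 also carry hydroxy there, and a weaker compound 4 is expected because the limit of > 100000 nM in this assay, at which 2 of the 3 values shown sit, is where both of them stand. Their chains differ from that of compound 4, so this guide is loose. In this assay the expected change (a 5.8-fold higher number from compound 3 to compound 4 (0.76 log units; beyond the scatter)) points clearly toward a weaker inhibitor. The estimate for compound 4 is 25000 nM within an expected range of 6000 nM to 100000 nM for this measurement.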

Compound 4, half-maximal inhibitory concentration: > 100000 nM
Compound 4 was reported as a limit; the forecaster's own chance of this, stated with the estimate: 35%; at least 4.0-fold (0.60 log units) between middle value and limit.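

In this assay, for the compounds shown here, methoxy to hydroxy on an oxygen on an aromatic ring is the first change whose size can be read, and it gives an at least 23-fold higher number from compound 3 to compound 4 (1.36 log units; beyond the scatter). The chain and the pyrrolidin-1-yl group stay the same in this pair, so the methyl on this oxygen alone separates a measurable value from none. Compound 4 now joins compound 1 and compound 2 at a limit of the assay, so the steps among these three hydroxy compounds cannot be read, and the limit is now the most common result: the limit of > 100000 nM in this assay, at which 3 of the 4 values shown sit.

As far as these compounds go, whether an ethoxy group on this oxygen would keep the activity of compound 3 remains open. So does whether methoxy there would also give a measurable value with the longer chain of compound 1 and compound 2.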